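A few compounds are considered here, and "the series" means these few. Any claim that something is new, unique, unknown or untested is made for them only; others in the source may bear on it.

Values in a functional assay on the whole organism for inhibition, with Felis catus as the target, with a stated time of 30 min; on this read-out higher numbers stand for an effect only at larger amounts of compound and lower numbers for an effect already at smaller amounts:
- compound 1 `OC(CNCCOc1ccccc1)COc1ccccc1` gives 0.054 mg/kg
- compound 2 `OC(CNCCOc1cccc(Cl)c1)COc1ccccc1` gives 0.375 mg/kg
- compound 3 `OC(CNCCOc1ccccc1F)COc1ccccc1` gives 0.081 mg/kg

Compound 3 (0.081 mg/kg) lies within the scatter of compound 1 (0.054 mg/kg) and well under compound 2 (0.375 mg/kg). Compound 4 `CCOCCNCC(O)COc1ccccc1` carries ethyl in place of 2-fluorophenyl on an oxygen on a saturated carbon. The measured steps only change substituents on the aromatic ring: a 1.5-fold higher number from compound 1 to compound 3 (0.18 log units; within the scatter), a 6.9-fold higher number from compound 1 to compound 2 (0.84 log units; beyond the scatter) and a 4.6-fold lower number from compound 2 to compound 3 (0.67 log units; beyond the scatter). None removes the ring, so they guide the size only loosely. A step to a higher number, about as large as the largest of these, is expected: a 6.2-fold higher number from compound 3 to compound 4 (0.79 log units; beyond the scatter). For compound 4 the estimated value is 0.5 mg/kg (0.1 mg/kg to 2.5 mg/kg).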

Compound 4, dose for half-maximal effect: 0.047 mg/kg
The estimate for compound 4 lay 11-fold (1.03 log units) above the measured number, and the stated range ends above it.
By their numbers in this assay, from the lowest: compounds 4, 1 and 3 (each within the scatter of the next); then compound 2.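

In this assay, the aromatic ring on this oxygen can give way to ethyl without leaving the scatter of the ring-bearing compound 1 (a 1.1-fold lower number from compound 1 to compound 4 (0.06 log units; within the scatter)) or compound 3 (a 1.7-fold lower number from compound 3 to compound 4 (0.24 log units; within the scatter)). Only the 3-chlorophenyl of compound 2 stands apart from ethyl (an 8.0-fold lower number from compound 2 to compound 4 (0.90 log units; beyond the scatter)), so among these compounds a ring at this place is not required for effect at small amounts. Nothing available explains this tolerance.

Open, as far as these compounds go, is whether a longer chain such as butyl, or a saturated ring such as cyclohexyl, would hold the number at this level. Also open, from the compounds shown here alone, is how a terminal amine or carboxylic acid on the ethyl would read out.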